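A few compounds are considered here, and "the series" means these few. Any claim that something is new, unique, unknown or untested is made for them only; others in the source may bear on it.

Measured so far:
compound 1 `CNC(=O)c1ccc(NCc2cncn2Cc2ccc(-c3ccccc3)cc2N)cc1-c1ccccc1` — > 1000 nM
compound 2 `COC(=O)c1ccc(NCc2cncn2Cc2ccccc2-c2ccccc2)cc1-c1ccccc1` — "not determined" (no result reported)

In a toxicity assay on NIH3T3 cells (Mus musculus) for cytotoxicity, read by resazurin assay (a higher number here means that more compound is needed for the effect, a lower number that less compound is needed), compound 1 gives > 1000 nM, which is a limit of the assay and not a number. In this assay compound 2 gives "not determined" (no result reported), so no number is shown for it; the only value in the set sits at the limit of > 1000 nM in this assay, at which 1 of the 2 values shown sits. Compound 3 `COC(=O)c1ccc(NCc2cncn2Cc2cccc(C(C)(C)C)c2)cc1-c1ccccc1` differs from compound 2 by 3-(tert-butyl)phenyl in place of 2-phenylphenyl on a saturated chain carbon bound to an aromatic nitrogen. No measured step is shown, so no direction beyond the scatter is expected for the step from compound 2 to compound 3 in this assay. With compound 1 at the limit of > 1000 nM in this assay, at which 1 of the 2 values shown sits, compound 3 is expected to give about 1500 nM, estimated between 400 nM and 6000 nM, most probably as a limit rather than a number.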

Compound 3, half-maximal effective concentration: > 1000 nM
Compound 3: only a limit was reported; the forecaster's own chance of this, stated with the estimate: 70%; the middle value lies beyond the limit too.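

Within the data shown here, no step from compound 2 to compound 3 can be read in this assay; compound 3 gives > 1000 nM, which is a limit and not a number. The compounds shown leave open how replacing 2-phenylphenyl with 3-(tert-butyl)phenyl affects the read-out, as the values stop at: the limit of > 1000 nM in this assay, at which 2 of the 3 values shown sit.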